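The source may report more compounds than this note shows. Statements on the series, on what has been measured and on what is new or still open speak of the compounds shown alone.

Measured compounds:
Compound 1, `Cc1cc(O)c(C2=NN(c3ccc(S(N)(=O)=O)cc3)C(c3ccccc3O)C2)cc1Cl`, in a functional assay on NCI-H23 cells (Homo sapiens) for antiproliferative activity, with a stated time of 48 h (a lower number here means a stronger inhibitor of growth, a higher number a weaker inhibitor of growth), compound 1 gives 5030 nM.
Compound 2, `Cc1cc(O)c(C2=NN(c3ccc(S(N)(=O)=O)cc3)C(c3ccccc3Cl)C2)cc1Cl`, gives 3580 nM.
Compound 3, `COc1ccc(C2CC(c3cc(Cl)c(C)cc3O)=NN2c2ccc(S(N)(=O)=O)cc2)cc1OC`, gives 13600 nM.

Compound 3 stands highest of the three numbers: the step of a 2.7-fold higher number from compound 1 to compound 3 (0.43 log units; beyond the scatter) and the step of a 3.8-fold higher number from compound 2 to compound 3 (0.58 log units; beyond the scatter) both lie beyond the scatter, while the step of a 1.4-fold lower number from compound 1 to compound 2 (0.15 log units; within the scatter) does not. Compound 4, `COc1ccc(C2CC(c3cc(Cl)c(C)cc3O)=NN2c2ccc(S(N)(=O)=O)cc2)c(OC)c1OC`, differs from compound 3 by methoxy in place of hydrogen on an aromatic carbon. Going by the values given here, no measured pair repeats this change, so nothing here bears on it directly. The two steps that touch compound 3 concern the whole aryl group on the saturated ring carbon, and both raised the number only modestly. A further methoxy on that same ring is a smaller change than either, so no step beyond the scatter is expected in this assay, with a slight lean toward a higher number. The expected step is a 1.2-fold higher number from compound 3 to compound 4 (0.07 log units; within the scatter). For compound 4 the estimate is 16000 nM, with a range from 6000 nM to 45000 nM.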

Compound 4, concentration for total growth inhibition: 5320 nM
Compound 4: middle estimate off by 3.0-fold (0.48 log units), on the high side; measured number outside the range, below it.
By their numbers in this assay, from the lowest: compounds 2, 1 and 4 (each within the scatter of the next); then compound 3.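

Adding methoxy to the 3,4-dimethoxyphenyl ring, at the place ortho to a large group, moves the number in this assay beyond the scatter, with a 2.6-fold lower number from compound 3 to compound 4 (0.41 log units; beyond the scatter), so this position on the aryl group is not silent in this assay. The resulting 2,3,4-trimethoxyphenyl group also stands level with the two aryl groups that carry a single group at that place, with a 1.5-fold higher number from compound 2 to compound 4 (0.17 log units; within the scatter) and a 1.1-fold higher number from compound 1 to compound 4 (0.02 log units; within the scatter), both within the scatter; among these four compounds, only compound 3 has no group there and only compound 3 stands apart. Nothing available here accounts for this step.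

On these data alone, it remains open whether a methoxy at this place would have the same effect without the other two methoxy groups. Also open, as far as these compounds go, is whether a fluoro or an amine there would give a number like that of compound 4 (5320 nM).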